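The source may report more compounds than this note shows. Statements on the series, on what has been measured and on what is new or still open speak of the compounds shown alone.

Measured so far:
Compound 1 `Cc1cc2cc(OCC(=O)O)ccc2n1Cc1ccc(O)c(C(C)C)c1` gives 16.3 nM in an assay on HeLa cells for displacement of a labelled ligand from thyroid hormone receptor alpha (Homo sapiens); on this read-out lower numbers stand for stronger inhibition and higher numbers for weaker inhibition.
Compound 2 `Cc1cc(OCC(=O)O)cc2ccn(Cc3ccc(O)c(C(C)C)c3)c12` gives 1.09 nM in this assay.
Compound 3 `CC(C)c1cc(Cn2ccc3cc(OCC(=O)O)cc(Cl)c32)ccc1O` gives 0.35 nM in this assay.

Compound 3 holds the lowest number of the three; compound 2 comes nearest, and compound 1 lies furthest away. Among the compounds with values here, the one single-point step in the set is a 3.1-fold lower number from compound 2 to compound 3 (0.49 log units; beyond the scatter), a modest gain beyond the scatter.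

Compound 4 `Cc1cc2cc(OCC(=O)O)cc(Cl)c2n1Cc1ccc(O)c(C(C)C)c1` is not yet measured. It differs from compound 3 by methyl in place of hydrogen on an aromatic carbon, the methyl sitting on the five-membered ring, next to the ring nitrogen. Within the data shown here, no measured step concerns this change: compound 1 carries the same methyl on its five-membered ring, but it also lacks the chloro of compound 3, so its values and those of compound 3 differ in two places at once and only show that compound 1 stands far higher. There is no basis for expecting a shift beyond the scatter in either direction. From the compounds shown here alone, compound 4 is therefore expected to land close to compound 3, at 0.6 nM with a range from 0.2 nM to 2.5 nM, a step of a 1.7-fold higher number from compound 3 to compound 4 (0.23 log units; within the scatter), kept wide because the change is untested here.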

Compound 4, inhibition constant: 0.38 nM
Compound 4: middle estimate off by 1.6-fold (0.20 log units), on the high side; measured number inside the range.
By their numbers in this assay, from the lowest: compounds 3 and 4 (each within the scatter of the next); then compound 2; then compound 1.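

With the chloro present, methyl in place of hydrogen on this aromatic carbon of the five-membered ring, next to the ring nitrogen, makes no difference beyond the scatter in this assay: the step is a 1.1-fold higher number from compound 3 to compound 4 (0.04 log units; within the scatter) and so this position accepts the methyl. Within the data shown here, the same compound also gives the first direct reading of the chloro with this methyl in place, a large step of a 43-fold lower number from compound 1 to compound 4 (1.63 log units; beyond the scatter), so in this pair the single change of chloro for hydrogen accounts for the whole gap. Nothing measured here gives a reason for either step.

Open remains whether an ethyl group, a longer chain or an amine on this same carbon would read like the methyl. Also open, from the compounds shown here alone, is whether bromo in place of the chloro would carry a step of similar size.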